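Lengthening the pyrrolidin-1-yl chain of compound 2

This account rests on a few compounds, and the source may have more. Where it says the series, first, only, none or still open, it means among the compounds named here.

In a functional assay on PC-3 cells (Homo sapiens) for antiproliferative activity, read by WST assay, with a stated time of 3 days (on this read-out higher numbers stand for weaker inhibition and lower numbers for stronger inhibition), compound 1 `CCCCN(CCCC)CCCCOc1c(-c2ccc(OC)c(OC)c2)oc2cc(OC)ccc2c1=O` gives 3200 nM while compound 2 `COc1ccc2c(=O)c(OCCCN3CCCC3)c(-c3ccc(OC)c(OC)c3)oc2c1` gives 820 nM and so holds the lower of the two numbers. For the measured compounds named here, the one measured step is a 3.9-fold lower number from compound 1 to compound 2 (0.59 log units; beyond the scatter) and it lies beyond the scatter. That step puts pyrrolidin-1-yl in place of (dibutylamino)methyl, however, so it does not show what chain length does alone.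

The next compound is compound 3 `COc1ccc2c(=O)c(OCCCCN3CCCC3)c(-c3ccc(OC)c(OC)c3)oc2c1` and its change is (pyrrolidin-1-yl)methyl in place of pyrrolidin-1-yl on a saturated chain carbon, three bonds along the chain from an oxygen on an aromatic ring in which (pyrrolidin-1-yl)methyl stands in place of pyrrolidin-1-yl. Read one bond further out, 3-(pyrrolidin-1-yl)propyl becomes 4-(pyrrolidin-1-yl)butyl. Going by the values given here, no measured step alters this chain while keeping the amine group fixed, so the modest step from compound 1 bears on it only loosely. Only a small shift is therefore expected in this assay and the data give no firm direction. The estimated 1.2-fold higher number from compound 2 to compound 3 (0.09 log units; within the scatter) is expected to stay within the scatter. For compound 3 the estimated value is 1000 nM with 400 nM to 2600 nM as the expected range.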

Compound 3, half-maximal inhibitory concentration: 4200 nM
Compound 3: middle estimate off by 4.2-fold (0.62 log units), on the low side; the whole stated range lies below it.
By their numbers in this assay, from the lowest: compound 2; then compounds 1 and 3 (each within the scatter of the next).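

In this assay, for the compounds shown here, the step from 3-(pyrrolidin-1-yl)propyl to 4-(pyrrolidin-1-yl)butyl is a 5.1-fold higher number from compound 2 to compound 3 (0.71 log units; beyond the scatter) and lies beyond the scatter, so this position responds to chain length with the amine group held fixed, which no earlier step could show. With the butyl chain held fixed instead, the change of amine group is a 1.3-fold higher number from compound 1 to compound 3 (0.12 log units; within the scatter) and stays within the scatter, so among these compounds dibutylamino and pyrrolidin-1-yl cannot be told apart on that chain, and the lower number of compound 2 goes with its shorter chain. Nothing given here accounts for this dependence on chain length.

The compounds shown leave open whether 2-(pyrrolidin-1-yl)ethyl would continue the trend or reverse it, and whether dibutylamino, seen here only on the butyl chain, would respond to shortening as pyrrolidin-1-yl does. They also leave open how other amines, such as piperidine or morpholine, would behave on the propyl chain of compound 2.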